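The compounds below may be only part of what the source reports. "The series", "measured", "known", "first", "only" and "open" are said of these compounds alone.

Measured so far:
compound 1 `CC(C)(N)C(=O)N[C@H](COCc1cccc(C(F)(F)F)c1)c1nnnn1CCOC(=O)NCCCCO` — 1.79 nM in a functional assay on cells for inhibition of growth hormone secretagogue receptor type 1 (Homo sapiens), read by FLIPR and calcium flux; on this read-out lower numbers stand for an effect already at smaller amounts and higher numbers for an effect only at larger amounts of compound
compound 2 `CC(C)(N)C(=O)N[C@H](COCc1ccccc1C#N)c1nnnn1CCOC(=O)NCCCCO` — 1.26 nM in this assay

Compound 2 sits at the low end of these two numbers, but the step of a 1.4-fold lower number from compound 1 to compound 2 (0.15 log units; within the scatter) lies within the scatter, so the two compounds are not separated on this read-out.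

Compound 3 `CC(C)(N)C(=O)N[C@H](COCc1ccccc1-c1cccnc1)c1nnnn1CCOC(=O)NCCCCO` differs from compound 2 by pyridin-3-yl in place of cyano on an aromatic carbon. Among the measured compounds shown here, the only measured step that bears on this position is the aryl exchange a 1.4-fold lower number from compound 1 to compound 2 (0.15 log units; within the scatter), which stayed within the scatter; the change to compound 3, however, brings in a full aromatic ring where a cyano group stood, a larger alteration than anything measured. For the measured compounds named here, with one within-scatter step as the sole guide, a small step is expected for compound 3, most likely toward a somewhat higher number, of about a 2.0-fold higher number from compound 2 to compound 3 (0.30 log units; within the scatter). Compound 3 is estimated at 2.5 nM, with a range from 0.8 nM to 8 nM.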

Compound 3, half-maximal effective concentration: 1.18 nM
Estimate against measurement, compound 3: 2.1-fold (0.33 log units) above; low and high end bracket the measured number.
By their numbers in this assay, from the lowest: compounds 3, 2 and 1 (each within the scatter of the next).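

In this assay, the aromatic carbon ortho to a large group accepts a whole six-membered aromatic ring where cyano stood, with no separation on this read-out: a 1.1-fold lower number from compound 2 to compound 3 (0.03 log units; within the scatter). The exchange of 3-(trifluoromethyl)phenyl for 2-(pyridin-3-yl)phenyl also stays within the scatter, at a 1.5-fold lower number from compound 1 to compound 3 (0.18 log units; within the scatter), so the three aryl groups shown are not told apart, and a much larger substituent has not moved the number beyond the scatter. Nothing available explains this flat result.

Still open, from the compounds shown here alone, is whether the same holds for a carboxylic acid or a primary amine on that aromatic carbon, where a group of a different charge would enter. A plain phenyl in place of pyridin-3-yl would show whether the ring nitrogen matters at all.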